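A few compounds are considered here, and "the series" means these few. Any claim that something is new, unique, unknown or untested is made for them only; others in the source may bear on it.

Compound 2, `COc1cccc(C(=O)N(C)c2ccc3[nH]c(-c4n[nH]c5ccccc45)cc3n2)c1`, is measured in a functional assay on A549 cells (Homo sapiens) for antiproliferative activity, read by MTT assay, with a stated time of 72 h; on this read-out higher numbers stand for weaker inhibition and lower numbers for stronger inhibition; in that assay compound 2 gives 14900 nM. Going by the values given here, its only companion is compound 1, `CN(C(=O)c1ccccc1)c1ccc2[nH]c(-c3n[nH]c4ccccc34)cc2n1`, which in this assay gives 13800 nM; the two values lie within the scatter of each other, so compound 2 stands level with compound 1 rather than apart from it. Among the compounds with values here, the single measured step, a 1.1-fold higher number from compound 1 to compound 2 (0.03 log units; within the scatter), concerns a methoxy in place of hydrogen on an aromatic carbon and stays within the scatter.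

Compound 3, `Cc1ccc(S(=O)(=O)N(C)c2ccc3[nH]c(-c4n[nH]c5ccccc45)cc3n2)cc1`, differs from compound 2 in that ((4-methylphenyl)sulfonyl in place of (3-methoxyphenyl)carbonyl on a nitrogen on an aromatic ring). Within the data shown here, no measured step touches this change: the one known step modifies the very group that is now exchanged wholesale, so it offers no guide to direction or size. With nothing in the series pointing either way, compound 3 is expected to move by a 1.0-fold higher number from compound 2 to compound 3 (0.00 log units; within the scatter) in this assay. The estimate for compound 3 is 15000 nM, with a range from 5000 nM to 45000 nM.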

Compound 3, half-maximal inhibitory concentration: 27100 nM
Compound 3: middle estimate off by 1.8-fold (0.26 log units), on the low side; the range from low to high includes it.
By their numbers in this assay, from the lowest: compounds 1, 2 and 3 (each within the scatter of the next).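

The earlier pair varied only a ring substituent on the carbonyl group, whereas compound 3 exchanges the whole group on a nitrogen on an aromatic ring, and in this assay this still gives only a 1.8-fold higher number from compound 2 to compound 3 (0.26 log units; within the scatter), and a 2.0-fold higher number from compound 1 to compound 3 (0.29 log units; within the scatter). All three compounds therefore stand level, so a sulfonyl in place of a carbonyl, with 4-methyl on the ring, does not separate compound 3 from either companion, although the step to compound 2 alters the linking group and the ring substituent together and cannot assign any share to either. Nothing available bears on why these values sit as they do.

The compounds shown leave open whether this level holds for a group of another kind at this nitrogen, such as a plain acetyl or a chain ending in an amine. They also leave open what a hydrogen in place of the saturated chain carbon on that nitrogen would give.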